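Moving the chlorine on the benzyl group: compound 3

The source may hold more compounds than are shown below. What is called first, only, known or untested is meant among the compounds shown, and "the series" means these compounds.

Measured so far in an assay on CHO cells for displacement of a labelled ligand from Alpha-1D adrenergic receptor (Homo sapiens); on this read-out higher numbers stand for weaker inhibition and lower numbers for stronger inhibition:
compound 1 `COc1cccc(OC)c1OCCNCCOc1ccccc1OCc1ccccc1`: 0.0676 nM
compound 2 `COc1cccc(OC)c1OCCNCCOc1ccccc1OCc1ccccc1Cl`: 0.251 nM

Among the compounds with values here, compound 2 stands with the highest of the two numbers; the single measured step is a 3.7-fold higher number from compound 1 to compound 2 (0.57 log units; beyond the scatter). Compound 3 `COc1cccc(OC)c1OCCNCCOc1ccccc1OCc1cccc(Cl)c1` has not been measured. It differs from compound 2 by 3-chlorophenyl in place of 2-chlorophenyl on a saturated chain carbon bound to an oxygen on an aromatic ring. Within the data shown here, no measured step moves a chlorine from one ring position to another; the only step at hand, a 3.7-fold higher number from compound 1 to compound 2 (0.57 log units; beyond the scatter), puts a chlorine where compound 1 had hydrogen. Whether that modest rise depends on the position of the chlorine cannot be read from these two compounds. The expectation for compound 3 is therefore a step of about a 1.4-fold lower number from compound 2 to compound 3 (0.14 log units; within the scatter), within the scatter or a slight easing back toward compound 1. For compound 3 the estimate in this assay is 0.18 nM, with a range from 0.06 nM to 0.6 nM.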

Compound 3, inhibition constant: 0.0501 nM
The estimate for compound 3 lay 3.6-fold (0.56 log units) above the measured number; the measured number lies below the stated range.
By their numbers in this assay, from the lowest: compounds 3 and 1 (each within the scatter of the next); then compound 2.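

In this assay, moving the chlorine gives a 5.0-fold lower number from compound 2 to compound 3 (0.70 log units; beyond the scatter) and shows that the rise seen on adding chlorine depends on where the chlorine sits on the benzyl ring, not on its presence alone. Set against the unsubstituted benzyl group, 3-chlorobenzyl gives a 1.3-fold lower number from compound 1 to compound 3 (0.13 log units; within the scatter) and so leaves the number where compound 1 had it, within the scatter. Among these three compounds, only the 2-chlorobenzyl group of compound 2 stands apart, and nothing at hand explains this difference between the two placements of the chlorine.

From the compounds shown here alone, whether the difference belongs to chlorine alone stays open: a fluorine, a methyl or a methoxy group in place of the chlorine of 2-chlorobenzyl and of 3-chlorobenzyl would test that. A bromine in the same two places would show whether a larger halogen follows the same course.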